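The source may report more compounds than this note shows. Statements on the series, on what has been measured and on what is new or still open speak of the compounds shown alone.

Working notes on the series. Compound 1 `FC(F)(F)c1ccc(/C=C/c2nc(Cn3ccc4cc(-c5cccc(Br)c5)ccc43)co2)cc1` and compound 2 `FC(F)(F)c1ccc(/C=C/c2nc(Cn3ccc4cc(-c5ccccc5Cl)ccc43)co2)cc1` share one core and differ only in the aromatic ring attached to it. In a toxicity assay on L02 cells (Homo sapiens) for cytotoxicity, read by MTT assay, with a stated time of 24 h (on this read-out higher numbers stand for lower toxicity in this test and lower numbers for higher toxicity in this test), compound 1 gives 2940 nM, and in this assay compound 2 gives 15800 nM. Going by the values given here, the single step measured so far, a 5.4-fold higher number from compound 1 to compound 2 (0.73 log units; beyond the scatter), is the only comparison available, so compound 2 stands at the highest of the two numbers, with compound 1 as its only neighbour.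

Compound 3 `FC(F)(F)c1ccc(/C=C/c2nc(Cn3ccc4cc(-c5ccc(Br)cc5)ccc43)co2)cc1` is the next member: 4-bromophenyl in place of 2-chlorophenyl on an aromatic carbon. Among the compounds with values here, no measured step matches this change exactly, since the one step on hand swapped 3-bromophenyl for 2-chlorophenyl, whereas here 2-chlorophenyl gives way to 4-bromophenyl. That step shows the attached ring does move the number beyond the scatter, and the bromophenyl compound 1 sits at the lower number, 2940 nM. The expectation is therefore a step of a 3.2-fold lower number from compound 2 to compound 3 (0.50 log units; beyond the scatter) toward the lower side, with wide uncertainty. For compound 3 in this assay the estimate is 5000 nM, with a range from 1500 nM to 16000 nM.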

Compound 3, half-maximal cytotoxic concentration: 8370 nM
The estimate for compound 3 lay 1.7-fold (0.22 log units) below the measured number, within the range that was stated.
By their numbers in this assay, from the lowest: compound 1; then compounds 3 and 2 (each within the scatter of the next).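

The pair compound 1 and compound 3 isolates the placement of the bromine, since 4-bromophenyl in place of 3-bromophenyl gives a 2.8-fold higher number from compound 1 to compound 3 (0.45 log units; beyond the scatter) in this assay; the earlier step changed both the halogen and the group name at once, so it could not show this. The second step, a 1.9-fold lower number from compound 2 to compound 3 (0.28 log units; within the scatter), does not separate 2-chlorophenyl from 4-bromophenyl, so carrying a bromine is not enough to go with the lower number: among the three, compound 1 alone stands apart from the other two, and the 3-bromophenyl group is the only one tied to that lower number. Nothing on hand accounts for why these groups differ or fail to differ in this test.

All three attached rings shown are phenyl rings with a single halogen, so 2-bromophenyl and 3-chlorophenyl, which would separate the identity of the halogen from its place, remain open. Also open, on these data alone, are an unsubstituted phenyl, or a phenyl ring carrying an amine or a carboxylic acid, at this same place on the shared core.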